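The source may hold more compounds than are shown below. What is called first, only, known or untested is meant among the compounds shown, and "the series" means these compounds.

Compound 1 `COc1cc2c(Oc3ccc(NC(=O)c4nn(-c5ccccc5OC(F)(F)F)c(=O)cc4C)cc3F)ccnc2cc1OCCCN1CCCCC1` gives the lowest of the three numbers in a functional assay on MKN-45 cells (Homo sapiens) for inhibition, read by MTT assay, with a stated time of 72 h (a higher number here means a weaker inhibitor, a lower number a stronger inhibitor), at 40 nM. Compound 2 `COc1cc2c(Oc3ccc(NC(=O)c4nn(-c5ccccc5OC(F)(F)F)c(=O)cc4C)cc3F)ccnc2cc1OCCCN1CCC(C)CC1` gives 70 nM in this assay, and the step of a 1.8-fold higher number from compound 1 to compound 2 (0.24 log units; within the scatter) stays within the usual scatter. Compound 3 `COc1cc2c(Oc3ccc(NC(=O)c4nn(-c5ccccc5OC(F)(F)F)c(=O)cc4C)cc3F)ccnc2cc1OCCCN1CCN(C)CC1` gives 100 nM in this assay, and the step of a 2.5-fold higher number from compound 1 to compound 3 (0.40 log units; beyond the scatter) is modest but beyond the scatter, while the step of a 1.4-fold higher number from compound 2 to compound 3 (0.15 log units; within the scatter) is again within it.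

Compound 4 `COc1cc2c(Oc3ccc(NC(=O)c4nn(-c5ccc(Cl)cc5)c(=O)cc4C)cc3F)ccnc2cc1OCCCN1CCCCC1` differs from compound 1 only in the change (4-chlorophenyl in place of 2-(trifluoromethoxy)phenyl on an aromatic nitrogen). None of the three measured steps touches this part of the molecule: all of them alter the amine at the end of the chain on the shared core, and the largest of them, from compound 1 to compound 3, is only modest. For the measured compounds named here, there is therefore no measured step that bears directly on the change from compound 1 to compound 4, and the steps that exist show the series tolerating small changes with only small shifts.

On that basis compound 4 is expected to give about 65 nM in this assay, with a plausible range from 15 nM to 280 nM. The expected step of a 1.6-fold higher number from compound 1 to compound 4 (0.21 log units; within the scatter) is a small weakening that may well fall within the scatter.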

Compound 4, half-maximal inhibitory concentration: 230 nM
For compound 4 the middle estimate is 3.5-fold (0.55 log units) below the measured one, and the stated range covers the measured number.
By their numbers in this assay, from the lowest: compounds 1, 2 and 3 (each within the scatter of the next, the first and the last beyond it); then compound 4.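

The group on the aromatic nitrogen turns out to matter to this assay: the step of a 5.8-fold higher number from compound 1 to compound 4 (0.76 log units; beyond the scatter) is beyond the scatter and larger than the largest step seen at the amine end of the chain, a 2.5-fold higher number from compound 1 to compound 3 (0.40 log units; beyond the scatter). So the tolerance seen among the amines does not extend to this position, at least for this replacement, and compound 4 is the weakest inhibitor of the four. The change replaces one substituent with another and also moves it around the phenyl ring, so this single step cannot assign the loss to either difference, and nothing available explains it in terms of a property of either group.

The compounds shown leave open whether the loss follows from removing the 2-(trifluoromethoxy) group or from introducing the 4-chloro group, a question that 2-chlorophenyl, 4-(trifluoromethoxy)phenyl or plain phenyl on the same nitrogen would help to separate. They also leave open whether a step of this size would recur with 4-methylpiperazin-1-yl or 4-methylpiperidin-1-yl at the end of the chain in place of piperidin-1-yl.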